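Ethyl for 1-methylcyclopropyl on a carbonyl carbon

This account rests on a few compounds, and the source may have more. Where it says the series, first, only, none or still open, it means among the compounds named here.

Compound 1 (`C[C@@H]1CN(c2nc(-c3cnn(C)c3)ncc2C#N)CCN1C(=O)C1(C)CC1`) is the starting point in an ADME assay on microsomes from liver (Rattus norvegicus) for pharmacokinetics; a higher number here means faster removal of the compound, a lower number slower removal. Compound 1 reads < 36 mL/min/kg, and this is a limit of the assay, not a number. Compound 2 (`C[C@@H]1CN(c2ncc(C#N)c(-c3cnn(C)c3)n2)CCN1C(=O)C1CC1`) does give a number in this assay, with compound 2 at 39 mL/min/kg. Compound 3 (`CCC(=O)N1CCN(c2nc(-c3cnn(C)c3)ncc2C#N)C[C@H]1C`) has not yet been measured. It differs from compound 1 at a single place, on a carbonyl carbon whose other neighbour is an amide-type nitrogen in a ring: ethyl in place of 1-methylcyclopropyl on a carbonyl carbon. Cut one bond further out, this reads (1-methylcyclopropyl)carbonyl to propanoyl. For the measured compounds named here, no measured pair sizes this change, so the expectation leans on the number for compound 2 at 39 mL/min/kg. The expected step, an at least 1.1-fold higher number from compound 1 to compound 3 (0.04 log units; that floor lies within the scatter), is none beyond the usual scatter, with no direction favoured. For compound 3 the estimate is 40 mL/min/kg, with an expected range of 24 mL/min/kg to 66 mL/min/kg.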

Compound 3, clearance: < 36 mL/min/kg
Compound 3 ended at the assay's limit (the forecaster's own chance of this, stated with the estimate: 45%); at least 1.1-fold (0.04 log units) between middle value and limit.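

No step can be read from compound 1 to compound 3 in this assay, because both compounds end at a limit of the assay: the limit of < 36 mL/min/kg in this assay, at which 2 of the 3 values shown sit. The compounds shown leave open how ethyl and 1-methylcyclopropyl on a carbonyl carbon compare in clearance.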